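Series notes: compound 4 as the cyanobenzyl analogue of compound 3

This account rests on a few compounds, and the source may have more. Where it says the series, first, only, none or still open, it means among the compounds named here.

Compound 3 `COC(=O)[C@H](CCSC)NC(=O)c1ccc(NCc2cncn2Cc2cccc([N+](=O)[O-])c2)cc1-c1ccccc1` is known in a functional assay on NIH3T3 cells (Mus musculus) (on this read-out higher numbers stand for an effect only at larger amounts of compound and lower numbers for an effect already at smaller amounts), only as a limit: compound 3 gives > 10 uM. Compound 2 `COC(=O)[C@H](CCSC)NC(=O)c1ccc(NCc2cncn2Cc2ccc(Cl)cc2)cc1-c1ccccc1` likewise shows a limit, > 10 uM. Compound 1 `CSCC[C@H](NC(=O)c1ccc(NCc2cncn2Cc2ccccc2C#N)cc1-c1ccccc1)C(=O)O`, with a free acid in place of the methyl ester, also sits at a limit, > 10 uM. For the measured compounds named here, the one measured step, a step that the two limits leave unreadable from compound 2 to compound 3, is unreadable since the limit of > 10 uM in this assay, at which 3 of the 3 values shown sit, holds every value shown. Compound 4 `COC(=O)[C@H](CCSC)NC(=O)c1ccc(NCc2cncn2Cc2ccccc2C#N)cc1-c1ccccc1` differs from compound 3 by 2-cyanophenyl in place of 3-nitrophenyl on a saturated chain carbon bound to an aromatic nitrogen. Compound 1 carries the same 2-cyanobenzyl group on a saturated chain carbon bound to an aromatic nitrogen, and its value is a limit as well. No readable step bears on this change, so no shift beyond the scatter is expected; the estimated step is a step that the limit leaves unreadable from compound 3 to compound 4. For compound 4 the expected value in this assay is 20 uM, within 8 uM to 60 uM, most likely reported again only as a limit.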

Compound 4, concentration for half-maximal effect: > 10 uM
Compound 4 was reported as a limit; the forecaster's own chance of this, stated with the estimate: 85%; the middle value does not contradict the limit.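

For the compounds shown here, no step from compound 1, compound 2 or compound 3 to compound 4 can be read: the limit of > 10 uM in this assay, at which 4 of the 4 values shown sit. The compounds shown leave open whether 2-cyanophenyl, 3-nitrophenyl, 4-chlorophenyl or the methyl on the ester changes the read-out at all.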